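This account rests on a few compounds, and the source may have more. Where it says the series, first, only, none or still open, it means among the compounds named here.

Compounds measured so far in a functional assay on MGC-803 cells (Homo sapiens) for inhibition, read by sulforhodamine B assay; on this read-out higher numbers stand for weaker inhibition and lower numbers for stronger inhibition:

Compound 1, `O=C1C(Nc2cccc(Cl)c2)=CC(=O)c2c1nc1n2[C@H]2OC[C@@H](O)[C@H]2OC1`: 1530 nM
Compound 2, `O=C1C(N2CCCCC2)=CC(=O)c2c1nc1n2[C@H]2OC[C@@H](O)[C@H]2OC1`: > 4000 nM, which is a limit of the assay and not a number
Compound 3, `O=C1C(Nc2ccccc2F)=CC(=O)c2c1nc1n2[C@H]2OC[C@@H](O)[C@H]2OC1`: 2000 nM

Of the two results that are actual numbers, compound 3 carries the higher one, but the step of a 1.3-fold higher number from compound 1 to compound 3 (0.12 log units; within the scatter) lies within the scatter, so compound 1 and compound 3 cannot be told apart. Compound 2 gave only a limit.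

Compound 4, `CCCN(CCC)C1=CC(=O)c2c(nc3n2[C@H]2OC[C@@H](O)[C@H]2OC3)C1=O`, is not yet measured in this assay. It differs from compound 3 in one place: dipropylamino in place of (2-fluorophenyl)amino on a double-bonded ring carbon. The group that enters has no aromatic ring and no hydrogen-bond donor, like piperidin-1-yl. Going by the values given here, two measured steps bear on such a swap. The step of an at least 2.6-fold higher number from compound 1 to compound 2 (0.41 log units; beyond the scatter) shows an at least modest weakening when (3-chlorophenyl)amino gives way to piperidin-1-yl, and the reverse move an at least 2.0-fold lower number from compound 2 to compound 3 (0.30 log units; that floor lies within the scatter) points back the other way. A weakening of at least modest size is therefore expected, with a fair chance that only a limit results, since the outcome for compound 2 was itself a limit (the limit of > 4000 nM in this assay, at which 1 of the 3 values shown sits).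

Compound 4 is estimated at 4500 nM, within a range from 2000 nM to 12000 nM. That estimate corresponds to an expected step of a 2.3-fold higher number from compound 3 to compound 4 (0.35 log units; beyond the scatter).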

Compound 4, half-maximal inhibitory concentration: > 16000 nM
Compound 4 ended at the assay's limit; the forecaster's own chance of this, stated with the estimate: 55%; middle value at least 3.5-fold (0.55 log units) away from the limit.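

In this assay, compound 4 gave a limit of the assay and not a number: the limit of > 16000 nM in this assay, at which 1 of the 4 values shown sits. Even so, the limit is high enough to show that a change at this double-bonded ring carbon can cost far more than the earlier compounds could reveal, with an at least 8.0-fold higher number from compound 3 to compound 4 (0.90 log units; beyond the scatter) and, for the swap from (3-chlorophenyl)amino, an at least 10-fold higher number from compound 1 to compound 4 (1.01 log units; beyond the scatter). Among the four compounds, the two with an aromatic ring and a hydrogen-bond donor in this group, compound 1 and compound 3, give numbers, while the two with neither, compound 2 and compound 4, give only limits, so the step between those last two cannot be read and no compound here goes against this pattern.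

Going by these compounds, these compounds remove the aromatic ring and the hydrogen-bond donor together, so it remains open which of the two matters, or whether both do. Cyclohexylamino, which keeps the amine hydrogen without an aromatic ring, and N-methylanilino, which keeps the aromatic ring without that hydrogen, would pull the two apart.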